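The source may report more compounds than this note shows. Statements on the series, on what has been measured and on what is new or still open speak of the compounds shown alone.

Compound 1 `COc1cc2c(Oc3ccc(NC(=O)c4nn(-c5ccccc5)c(=O)cc4C)cc3F)ccnc2cc1OCCCN1CCN(C)CC1` and compound 2 `COc1cc2c(Oc3ccc(NC(=O)c4nn(-c5ccccc5OC(F)(F)F)c(=O)cc4C)cc3F)ccnc2cc1OCCCN1CCCCC1` share the same core and differ from each other at two places. In a functional assay on U-87MG ATCC cells (Homo sapiens) for inhibition, read by MTT assay, with a stated time of 72 h (a lower number here means a stronger inhibitor, a higher number a weaker inhibitor), compound 1 gives 2120 nM, and in this assay compound 2 gives 1300 nM. The two numbers lie within the usual scatter of each other, so compound 2 does not stand apart from compound 1 in this assay. Compound 3 `COc1cc2c(Oc3ccc(NC(=O)c4nn(-c5ccccc5OC(F)(F)F)c(=O)cc4C)cc3F)ccnc2cc1OCCCN1CCN(C)CC1` keeps the trifluoromethoxy-bearing side of compound 2 and changes only the amine end of the chain: 4-methylpiperazin-1-yl in place of piperidin-1-yl on a saturated chain carbon, three bonds along the chain from an oxygen on an aromatic ring. Among the compounds with values here, no measured pair isolates this single change. Compound 1 carries the entering group and gives 2120 nM; compound 2 carries the leaving group and gives 1300 nM; these two lie within the scatter. On that basis the step of a 1.2-fold higher number from compound 2 to compound 3 (0.06 log units; within the scatter) is expected to be small, in neither direction beyond the scatter. Compound 3 is therefore expected to give 1500 nM, within a range from 600 nM to 4000 nM.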

Compound 3, half-maximal inhibitory concentration: 1440 nM
Compound 3: the middle estimate sits 1.0-fold (0.02 log units) above what was measured; the range from low to high includes it.
By their numbers in this assay, from the lowest: compounds 2, 3 and 1 (each within the scatter of the next).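

In this assay the replacement of piperidin-1-yl by 4-methylpiperazin-1-yl on a saturated chain carbon can now be read on its own as a 1.1-fold higher number from compound 2 to compound 3 (0.04 log units; within the scatter) and so makes no difference that can be told from the scatter at this position. Trifluoromethoxy in place of hydrogen on an aromatic carbon can also be read alone as a 1.5-fold lower number from compound 1 to compound 3 (0.17 log units; within the scatter) and likewise stays inside the scatter, so neither single difference separates these compounds in this assay. Nothing at hand bears on why these steps are so small.

As far as these compounds go, whether morpholine or dimethylamine at the end of the chain, or a longer chain, would give a step beyond the scatter remains open. From the compounds shown here alone, it is equally open whether chlorine or methoxy in place of trifluoromethoxy would do so.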